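The source may report more compounds than this note shows. Statements on the series, on what has been measured and on what is new or still open speak of the compounds shown alone.

Measured compounds:
compound 1 `CN1CCC(c2c[nH]c3cnc(NC(=O)c4ccc(F)cc4)cc23)CC1`, which in an assay for binding affinity to 5-hydroxytryptamine receptor 1F (Homo sapiens), read by radioligand binding (a higher number here means a weaker inhibitor, a lower number a stronger inhibitor), gives 13 nM
compound 2 `CC(=O)Nc1cc2c(C3CCN(C)CC3)c[nH]c2cn1`, which in this assay gives 210 nM
compound 3 `CN1CCC(c2c[nH]c3ccc(NC(=O)c4cccc(F)c4)nc23)CC1`, which in this assay gives 11 nM

Compound 3 has the lowest of the three numbers. Its nearest neighbour is compound 1, and the gap between the two lies within the scatter, so neither can be called the stronger binder. Compound 2 stands much higher, well beyond the scatter from both.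

Compound 4 `CCCCC(=O)Nc1ccc2[nH]cc(C3CCN(C)CC3)c2n1` has not yet been measured. It differs from compound 3 in one place: butyl in place of 3-fluorophenyl on a carbonyl carbon. Among the measured compounds shown here, one measured step bears on this change. From compound 1 to compound 2, the group on the same carbonyl carbon shrinks from an aromatic ring to a methyl, and the number rises sharply: a 16-fold higher number from compound 1 to compound 2 (1.21 log units; beyond the scatter). The change to compound 4 also removes the aromatic ring, but the butyl that enters is a longer chain than methyl, so the loss is expected to be in the same direction yet smaller than that seen from compound 1 to compound 2. Compound 4 is therefore expected to give 60 nM in this assay, with a likely range from 20 nM to 200 nM, which would mean an expected step of a 5.5-fold higher number from compound 3 to compound 4 (0.74 log units; beyond the scatter).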

Compound 4, inhibition constant: 14 nM
For compound 4 the middle estimate is 4.3-fold (0.63 log units) above the measured one, outside the stated range (below it).
By their numbers in this assay, from the lowest: compounds 3, 1 and 4 (each within the scatter of the next); then compound 2.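

In this assay, replacing 3-fluorophenyl with butyl on the carbonyl carbon leaves the number unchanged within the scatter (a 1.3-fold higher number from compound 3 to compound 4 (0.10 log units; within the scatter)), so on the core of compound 3 an aromatic ring is not needed at this position for binding at this level. The earlier pair had linked the loss of an aromatic ring to a large rise (a 16-fold higher number from compound 1 to compound 2 (1.21 log units; beyond the scatter)), but the new step shows that losing the ring does not by itself bring such a rise, and that the rise may instead belong to methyl specifically or to the core of compound 1. Nothing measured here explains why butyl and 3-fluorophenyl give numbers within the scatter of each other.

The compounds shown leave open whether the contrast between the two steps comes from the chain or from the core, which a methyl on the core of compound 3 or a butyl on the core of compound 1 would separate. They also leave open how far this tolerance extends, for example to a longer chain, a branched chain such as tert-butyl, or a chain ending in an amine or a carboxylic acid.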